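The source may report more compounds than this note shows. Statements on the series, on what has been measured and on what is new or still open speak of the compounds shown alone.

Compound 1 `CCOc1cc(COc2cccc(F)c2)nc(-c2ccccn2)n1`: 251 nM
Compound 2 `CN(C)c1cc(COc2cccc(F)c2)nc(-c2ccccn2)n1`: 1580 nM

Both numbers come from a functional assay on cells for antagonist activity at Free fatty acid receptor 1 (Homo sapiens), read by TR-FRET and inositol phosphate accumulation, with a stated time of 2 h; a lower number here means a stronger inhibitor, a higher number a weaker inhibitor. Going by the values given here, of the two, compound 2 has the higher number, its only neighbour being compound 1; that step was a 6.3-fold higher number from compound 1 to compound 2 (0.80 log units; beyond the scatter), so compound 2 is the weaker of the pair in this assay. Compound 3 `CCNc1cc(COc2cccc(F)c2)nc(-c2ccccn2)n1` is not yet measured. It differs from compound 2 in one place: ethylamino in place of dimethylamino on an aromatic carbon. Among the compounds with values here, only one measured step touches this position, and it exchanged a different pair of groups, so it is a loose guide at best; it shows that swapping a small group here can move the number by a modest amount. A modest step in this assay is therefore expected, leaning toward a lower number, though none beyond the scatter is also possible. Compound 3 is expected to give about 800 nM, within 250 nM to 2500 nM. The expected step in this assay is a 2.0-fold lower number from compound 2 to compound 3 (0.30 log units; within the scatter).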

Compound 3, half-maximal inhibitory concentration in the Free fatty acid receptor 1 assay: 631 nM
Compound 3: middle estimate off by 1.3-fold (0.10 log units), on the high side; low and high end bracket the measured number.
By their numbers in the Free fatty acid receptor 1 assay, from the lowest: compound 1; then compound 3; then compound 2.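

In the Free fatty acid receptor 1 assay swapping dimethylamino in compound 2 (1580 nM) for ethylamino in compound 3 (631 nM) keeps the same heavy atoms but adds a hydrogen-bond donor, and it moves the number beyond the scatter (a 2.5-fold lower number from compound 2 to compound 3 (0.40 log units; beyond the scatter)), so how these atoms are joined matters at this position, not only which atoms are present. Ethylamino still does not match ethoxy (a 2.5-fold higher number from compound 1 to compound 3 (0.40 log units; beyond the scatter)), so among these three groups ethoxy gives the strongest inhibitor and dimethylamino the weakest. In a physicochemical assay for lipophilicity, at pH 7.4 (on this read-out lower numbers stand for lower lipophilicity and higher numbers for higher lipophilicity), compound 2 gives 3.6 and compound 3 gives 3.9, and the same swap stays within the scatter (a number 0.30 log units higher from compound 2 to compound 3 (within the scatter)), and nothing available gives a reason for the differences in inhibition.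

From the compounds shown here alone, whether a plain amine, methylamino or a longer chain such as propylamino would come closer to ethoxy remains open. So does whether the added donor itself accounts for the step between the two amines.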